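Swapping the indanylamine of compound 2 for a sulfonamide

The source may report more compounds than this note shows. Statements on the series, on what has been measured and on what is new or still open speak of the compounds shown alone.

Compound 2 `c1ccc2c(c1)CCC2NC1CCN(CCCc2c[nH]c3ccc(-n4cnnc4)cc23)CC1` is one of two close relatives examined in an assay on CHO cells for displacement of a labelled ligand from 5-hydroxytryptamine receptor 1B (Homo sapiens); a lower number here means a stronger inhibitor, a higher number a weaker inhibitor. In this assay, within the data shown here, compound 2 gives 280 nM; its only neighbour, compound 1 `O[C@H]1Cc2ccccc2C1NC1CCN(CCCc2c[nH]c3ccc(-n4cnnc4)cc23)CC1`, gives 300 nM. Among the measured compounds shown here, the single measured step, a 1.1-fold lower number from compound 1 to compound 2 (0.03 log units; within the scatter), shows that removing the hydroxy from the saturated ring barely moves the number, so compound 2 stands alongside compound 1 rather than apart from it.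

Compound 3 `CN(C1CCN(CCCc2c[nH]c3ccc(-n4cnnc4)cc23)CC1)S(=O)(=O)c1ccccc1` has not been measured. It differs from compound 2 by methyl(phenylsulfonyl)amino in place of (2,3-dihydro-1H-inden-1-yl)amino on a saturated ring carbon. For the measured compounds named here, this is a far larger alteration than the one between compound 1 and compound 2: the whole indane unit goes, and with it the only donor at that position, while a sulfonyl group brings two new acceptors. Going by the values given here, no measured step touches this kind of exchange, so the step from compound 1 to compound 2 offers no guide to its size or direction.

On that basis the estimate for compound 3 is 700 nM, within a broad range from 100 nM to 5000 nM, corresponding to an expected step of a 2.5-fold higher number from compound 2 to compound 3 (0.40 log units; beyond the scatter).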

Compound 3, half-maximal inhibitory concentration: 10 nM
Compound 3: the middle estimate sits 70-fold (1.85 log units) above what was measured; measured number below the stated range.
By their numbers in this assay, from the lowest: compound 3; then compounds 2 and 1 (each within the scatter of the next).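

Exchanging the (2,3-dihydro-1H-inden-1-yl)amino group for methyl(phenylsulfonyl)amino on this saturated ring carbon gives a 28-fold lower number from compound 2 to compound 3 (1.45 log units; beyond the scatter) in this assay, and the same exchange made on the hydroxy-bearing group gives a 30-fold lower number from compound 1 to compound 3 (1.48 log units; beyond the scatter). The earlier pair differed only by a hydroxy on the indane and hardly separated in number, so it gave no sign that this position could matter so much; these large steps show that it does. They also show that neither the indane nor a hydrogen-bond donor in the group at this position is needed for a low number, since the entering group has neither, and the data shown offer no explanation for the gain.

The compounds shown change the whole group at once, so they do not tell which part of methyl(phenylsulfonyl)amino carries the gain. On these data alone, whether the low number would survive a hydrogen in place of the methyl, a carbonyl in place of the sulfonyl, or a pyridine ring in place of the phenyl remains open.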